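Moving the methoxy group on the aryl imine: expected clearance

A few compounds are considered here, and "the series" means these few. Any claim that something is new, unique, unknown or untested is made for them only; others in the source may bear on it.

Compound 1 `CCC1(CC)CS/C(=N\c2ccccc2C(C)C)N(C(=S)SC)C1`: 48.3 mL/min/kg
Compound 2 `CSC(=S)N1CC2(CC2)CS/C1=N\c1ccccc1C(C)C`: 85.1 mL/min/kg
Compound 3 `COc1ccccc1/N=C1\SCC2(CCCCC2)CN1C(=S)SC`: 75.9 mL/min/kg

In an in vivo ADME assay on the whole organism for pharmacokinetics, with Rattus norvegicus as the target (on this read-out higher numbers stand for fast clearance and lower numbers for slow clearance), compound 3 gives 75.9 mL/min/kg, which is the second highest of the three numbers. Its nearest neighbour is compound 2 with 85.1 mL/min/kg, and the gap between the two is within the usual scatter. The furthest is compound 1 with 48.3 mL/min/kg, and that gap also lies within the scatter, so the three measured compounds cannot be told apart on this read-out.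

Compound 4 `COc1cccc(/N=C2\SCC3(CCCCC3)CN2C(=S)SC)c1` is the next compound to be measured. It differs from compound 3 in one place: 3-methoxyphenyl in place of 2-methoxyphenyl on a double-bonded nitrogen. The two share every atom, joined differently. Going by the values given here, no pair of measured compounds differs by a change of this kind, so there is no measured step to lean on. Given that compound 3 gives 75.9 mL/min/kg and that all three measured numbers sit within the scatter of each other, the step from compound 3 to compound 4 is expected to be small, in no particular direction, and most likely not beyond the scatter: a 1.0-fold lower number from compound 3 to compound 4 (0.01 log units; within the scatter). For compound 4 the estimated clearance is 75 mL/min/kg, with a range from 40 mL/min/kg to 140 mL/min/kg.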

Compound 4, clearance: 45.1 mL/min/kg
Estimate against measurement, compound 4: 1.7-fold (0.22 log units) above, and the stated range covers the measured number.
By their numbers in this assay, from the lowest: compounds 4, 1, 3 and 2 (each within the scatter of the next).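

In this assay, putting 3-methoxyphenyl in place of 2-methoxyphenyl on a double-bonded nitrogen gives a 1.7-fold lower number from compound 3 to compound 4 (0.23 log units; within the scatter). Going by these compounds alone, this is the first step that changes one place alone, and it shows that moving the methoxy group around the phenyl ring, with the same atoms joined differently and the shared core kept, does not separate the two compounds on this read-out, since the two values cannot be told apart. No independent measurement bears on this result, so nothing can be said about what lies behind the size of the step.

The compounds shown leave open whether a different group on the phenyl ring in place of the methoxy group, such as an amine, a carboxylic acid or a longer alkoxy chain, would give a step beyond the scatter on the core of compound 3. They also leave open whether the same move of the methoxy group would give a similar step on the cores of compound 1 and compound 2, which carry another aryl group and differ from compound 3 in more than one place.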